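Lengthening a Chain on a Urea-Based Cholesterol Acyltransferase Inhibitor

The source may report more compounds than this note shows. Statements on the series, on what has been measured and on what is new or still open speak of the compounds shown alone.

Three ureas share one core and differ only in the chain on one ring. Compound 1 `CCCCc1ccc(NC(=O)Nc2c(C(C)C)cccc2C(C)C)cc1` gives 29 nM in an assay on isolated protein for inhibition of acyl-CoA:cholesterol acyltransferase (Oryctolagus cuniculus); a higher number here means a weaker inhibitor, a lower number a stronger inhibitor. Compound 2 `CCCCCCCCCCCCc1ccc(NC(=O)Nc2c(C(C)C)cccc2C(C)C)cc1` gives 15 nM in this assay, and compound 3 `Cc1ccc(NC(=O)Nc2c(C(C)C)cccc2C(C)C)cc1` gives 250 nM. The difference between compound 1 and compound 3 is hydrogen in place of propyl on a saturated chain carbon bound to an aromatic carbon. Going from compound 1 to compound 2 the change is octyl in place of hydrogen on a saturated chain carbon, four bonds along the chain from an aromatic carbon, and the step is a 1.9-fold lower number from compound 1 to compound 2 (0.29 log units; within the scatter). Compound 4 `CCCCCCCCCc1ccc(NC(=O)Nc2c(C(C)C)cccc2C(C)C)cc1` is not yet measured; it differs from compound 3 by octyl in place of hydrogen on a saturated chain carbon bound to an aromatic carbon. This is the same kind of change, but the place differs: bound to an aromatic carbon, rather than four bonds along the chain from an aromatic carbon. Because removing the chain gave an 8.6-fold higher number from compound 1 to compound 3 (0.94 log units; beyond the scatter), and the further growth gave only a 1.9-fold lower number from compound 1 to compound 2 (0.29 log units; within the scatter), compound 4 is expected to land between them, a step of a 13-fold lower number from compound 3 to compound 4 (1.10 log units; beyond the scatter). Compound 4 is estimated at 20 nM, with a range of 8 nM to 50 nM.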

Compound 4, half-maximal inhibitory concentration: 9 nM
For compound 4 the middle estimate is 2.2-fold (0.35 log units) above the measured one; low and high end bracket the measured number.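

In this assay, the octyl change does not carry over from one core to another at a single size: the same change on two cores in this assay, a 1.9-fold lower number (0.29 log units; within the scatter) from compound 1 to compound 2 and a 28-fold lower number (1.44 log units; beyond the scatter) from compound 3 to compound 4, 14-fold (1.16 log units) apart, beyond the scatter of two such steps

Removing propyl likewise depends on the core it is made on: the same change on two cores in this assay, an 8.6-fold higher number (0.94 log units; beyond the scatter) from compound 1 to compound 3 and a 1.7-fold lower number (0.22 log units; within the scatter) from compound 2 to compound 4, 14-fold (1.16 log units) apart, beyond the scatter of two such steps

The new steps are a 28-fold lower number from compound 3 to compound 4 (1.44 log units; beyond the scatter), a 3.2-fold lower number from compound 1 to compound 4 (0.51 log units; beyond the scatter) and a 1.7-fold lower number from compound 2 to compound 4 (0.22 log units; within the scatter), so the last of these does not separate the two longest chains; they show that the size of a chain change depends on the chain already present in these four compounds, but not why, nor whether this holds on any other core.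

Still open, going by these compounds, is how a chain longer than that of compound 2 would compare. Also open, on these data alone, is whether a chain carrying an amine or a carboxylic acid would follow these plain carbon chains.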